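The source may hold more compounds than are shown below. What is called first, only, known or untested is meant among the compounds shown, and "the series" means these compounds.

Measured compounds:
- compound 1 `CCC(C)C1NC(=O)N(C2CCCC2)C1=O`: > 100000 nM
- compound 2 `CC(C)C(NC(=O)NO)C(=O)NC1CCCC1`: 33400 nM
- compound 3 `CCC(C)C(NC(=O)n1nnc2ccccc21)C(=O)NC1CCCCC1`: 57900 nM

All three were run in a functional assay on HEp-2 cells (Homo sapiens) for inhibition; on this read-out higher numbers stand for weaker inhibition and lower numbers for stronger inhibition. For compound 1 the value is not a number but a limit of the assay, > 100000 nM; this is the limit of > 100000 nM in this assay, at which 1 of the 3 values shown sits. The two numbers that remain are those of compound 2 and compound 3. In this assay compound 3 gives 57900 nM and compound 2 gives 33400 nM; the gap between them lies within the scatter, so no order can be read between the two, and compound 3 stands with compound 2 at the same level on the numbers shown. Compound 1 is known only as a limit.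

Compound 4 `CCC(C)C(NC(=O)n1nnc2ccccc21)C(=O)NCc1ccccc1` differs from compound 3 in one place: benzyl in place of cyclohexyl on an amide-type nitrogen. Among the measured compounds shown here, no step between measured compounds touches this position, so there is no measured guide for its size. The working expectation is no step beyond the scatter, in either direction. The expected step of a 1.1-fold lower number from compound 3 to compound 4 (0.02 log units; within the scatter) therefore stays small. For compound 4 the estimate in this assay is 55000 nM, with a range from 18000 nM to 170000 nM.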

Compound 4, half-maximal inhibitory concentration: > 100000 nM
Compound 4: a limit, no number; the forecaster's own chance of this, stated with the estimate: 35%; at least 1.8-fold (0.25 log units) between middle value and limit.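

Compound 4 in this assay gives > 100000 nM, which is a limit of the assay and not a number. Among the compounds shown here, this gives the first measured step at this position, an at least 1.7-fold higher number from compound 3 to compound 4 (0.23 log units; that floor lies within the scatter), so benzyl on the amide-type nitrogen does not match cyclohexyl as a measured number, yet the step is only a floor and does not establish a change beyond the scatter. The values of the series now reach the top of the readable range more often: the limit of > 100000 nM in this assay, at which 2 of the 4 values shown sit.

On these data alone, the true size of the step remains open, and with it whether this position matters for the read-out at all. Also open, as far as these compounds go, is how a longer chain such as phenethyl, a phenyl group placed directly on this nitrogen, or a cyclohexyl group carrying an amine would read here.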